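The source may hold more compounds than are shown below. What is called first, only, known or untested is meant among the compounds shown, and "the series" means these compounds.

Among the compounds with values here, in a physicochemical assay for metabolic stability, at 50 degrees C, tested at 5 uM (on this read-out lower numbers stand for a shorter-lived compound and higher numbers for a longer-lived compound), compound 1 `Cc1ccc(CO[P@@]2(=O)OC[C@H]3O[C@@H](n4cnc5c(N)ncnc54)[C@H](O)[C@@H]3O2)cc1` gives 0.1 h, the lower of the two numbers so far. Compound 2 `Nc1ncnc2c1ncn2[C@@H]1O[C@@H]2CO[P@@](=O)(OCc3ccc([N+](=O)[O-])cc3)O[C@H]2[C@H]1O` gives 73 h. The gap between these two numbers lies far beyond the usual scatter. Compound 3 `Nc1ncnc2c1ncn2[C@@H]1O[C@@H]2CO[P@](=O)(OCc3ccccc3)O[C@H]2[C@H]1O` has not yet been measured. It differs from compound 1 by hydrogen in place of methyl on an aromatic carbon. Within the data shown here, no two measured compounds differ in one place only, so direct guidance is missing. In this assay the expected step of a 4.0-fold higher number from compound 1 to compound 3 (0.60 log units; beyond the scatter) is a rise, estimated to lie modestly beyond the scatter. For compound 3 the estimate is 0.4 h, with an expected range from 0.12 h to 1.5 h.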

Compound 3, half-life: 2.2 h
For compound 3 the middle estimate is 5.5-fold (0.74 log units) below the measured one, and the stated range ends below it.
By their numbers in this assay, from the lowest: compound 1; then compound 3; then compound 2.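

In this assay, putting hydrogen in place of methyl, which turns 4-methylbenzyl into benzyl, gives a 22-fold higher number from compound 1 to compound 3 (1.34 log units; beyond the scatter). This aromatic carbon, para to a large group, is therefore a sensitive place: losing one carbon there moves the half-life well beyond the scatter. Nothing available explains why this small change has so large an effect.

Still open, as far as these compounds go, is how other groups at this same carbon would behave, such as an amine, a carboxylic acid or a longer chain like ethyl. From the compounds shown here alone, whether the same swap would have a similar effect on another core also remains unknown.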